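Adding a methoxy group to compound 2

A few compounds are considered here, and "the series" means these few. Any claim that something is new, unique, unknown or untested is made for them only; others in the source may bear on it.

In a functional assay on L1210 cells (Mus musculus) for antiproliferative activity, with a stated time of 48 h (a higher number here means a weaker inhibitor, a lower number a stronger inhibitor), compound 1 `C=C(Br)C(=O)Nc1ccc(C(=O)/C=C/c2ccc(OC)c(OC)c2)cc1` gives 1300 nM and compound 2 `C=C(Br)C(=O)Nc1ccc(C(=O)/C=C/c2cc(OC)cc(OC)c2)cc1` gives 2700 nM as the higher of the two numbers, a gap beyond the usual scatter. Compound 3 `C=C(Br)C(=O)Nc1ccc(C(=O)/C=C/c2cc(OC)c(OC)c(OC)c2)cc1` differs from compound 2 by methoxy in place of hydrogen on an aromatic carbon in one place: methoxy in place of hydrogen on an aromatic carbon, ortho to two methoxy groups and para to a large group. For the measured compounds named here, no measured step shows this change directly. Going by the values given here, compound 1 at 1300 nM is the only guide, and it suggests that a lower number is within reach. A modest fall is expected in this assay with the estimated step of a 2.7-fold lower number from compound 2 to compound 3 (0.43 log units; beyond the scatter) at its centre. For compound 3 the estimated value is 1000 nM within an expected range of 300 nM to 2800 nM in this measurement.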

Compound 3, half-maximal inhibitory concentration: 1500 nM
For compound 3 the middle estimate is 1.5-fold (0.18 log units) below the measured one; the measured number falls inside the stated range.
By their numbers in this assay, from the lowest: compounds 1, 3 and 2 (each within the scatter of the next, the first and the last beyond it).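

In this assay, methoxy at this position, ortho to two methoxy groups and para to a large group, gives a 1.8-fold lower number from compound 2 to compound 3 (0.26 log units; within the scatter) and so brings no change that can be told from the scatter. The same kind of change read from the other side gives a 1.2-fold higher number from compound 1 to compound 3 (0.06 log units; within the scatter) and so leaves compound 3 also unresolved from compound 1. Nothing measured accounts for these numbers. As far as these compounds go, whether a hydroxyl, an amine or a longer alkoxy chain at this position would move the number beyond the scatter stays open.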